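A dimethylphenyl swap on an inactive compound

The source may report more compounds than this note shows. Statements on the series, on what has been measured and on what is new or still open speak of the compounds shown alone.

In a functional assay on HL-60 cells (Homo sapiens) for inhibition, read by MTT assay, with a stated time of 72 h (on this read-out lower numbers stand for stronger inhibition and higher numbers for weaker inhibition), compound 1 (`Cc1ccc(C)c(N2CCN(C(=O)c3oc(C)nc3-c3ccccc3F)CC2)c1`) gives 319 nM. Compound 2 (`COc1cccc(N2CCN(C(=O)c3oc(C)nc3-c3cccc(F)c3)CC2)c1`) is reported as "not active" (no number reported), which leaves it with no single number on this read-out. Compound 3 (`Cc1ccc(C)c(N2CCN(C(=O)c3oc(C)nc3-c3cccc(F)c3)CC2)c1`) awaits measurement, and the structural change leading to it is 2,5-dimethylphenyl in place of 3-methoxyphenyl on an amine nitrogen in a ring. In words, 2,5-dimethylphenyl stands in place of 3-methoxyphenyl on an amine nitrogen in a ring. Among the compounds with values here, the same 2,5-dimethylphenyl is carried by compound 1, whose 319 nM is the only number available to lean on. Within the data shown here, no measured step shows what this change does, and without a number for compound 2 its size cannot be stated exactly. The expected step in this assay is towards stronger inhibition, from no reported number to a measurable one. Compound 3 is expected at about 600 nM, with an estimated range of 150 nM to 3000 nM.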

Compound 3, half-maximal inhibitory concentration: 204 nM
For compound 3 the middle estimate is 2.9-fold (0.47 log units) above the measured one, and the stated range covers the measured number.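

In this assay the change from 3-methoxyphenyl to 2,5-dimethylphenyl on the amine nitrogen in the ring separates compound 2, reported as not active, from compound 3 at 204 nM, although compound 2 has no number and the size of this step cannot be read. With 2,5-dimethylphenyl held constant, 3-fluorophenyl in place of 2-fluorophenyl gives a 1.6-fold lower number from compound 1 to compound 3 (0.19 log units; within the scatter), so these two fluorophenyl groups are not told apart on this read-out. Nothing in the available evidence explains the difference between compound 2 and compound 3.

The compounds shown leave open whether both methyl groups of the 2,5-dimethylphenyl are needed, or whether a plain phenyl or a 2,5-dimethoxyphenyl on that nitrogen would also give a measurable number. They also leave open whether 3-methoxyphenyl would read as not active alongside 2-fluorophenyl.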